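The compounds below may be only part of what the source reports. "The series", "measured", "known", "first", "only" and "open" are said of these compounds alone.

Three compounds share one core and carry a hydrazone arm ending in a benzene ring. Compound 1 `O=C(CCc1nc2ccccc2c(=O)[nH]1)N/N=C/c1ccc(O)cc1` gives 238000000 nM in a physicochemical assay, read by spectrophotometry, with a stated time of 30 min; a higher number here means a weaker inhibitor, a lower number a stronger inhibitor. Compound 2 `O=C(CCc1nc2ccccc2c(=O)[nH]1)N/N=C/c1ccccc1` gives 734000000 nM in this assay. Compound 3 `O=C(CCCc1nc2ccccc2c(=O)[nH]1)N/N=C/c1ccc(O)cc1` gives 214000000 nM in this assay. The difference between the cores of compound 2 and compound 3 is not broken down here. Compound 1 and compound 3 show values that lie within the scatter of each other. Within the data shown here, the single change from compound 2 to compound 1 is hydroxy in place of hydrogen on an aromatic carbon, and it brings a 3.1-fold lower number from compound 2 to compound 1 (0.49 log units; beyond the scatter).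

Compound 4 `O=C(CCCc1nc2ccccc2c(=O)[nH]1)N/N=C/c1ccc(O)c(O)c1` has not yet been measured. It differs from compound 3 by hydroxy in place of hydrogen on an aromatic carbon. This is the same kind of change as from compound 2 to compound 1, though the surroundings differ: there the entering group stood para to a large group, here it stands ortho to a hydroxy group and meta to a large group. On the strength of a 3.1-fold lower number from compound 2 to compound 1 (0.49 log units; beyond the scatter), compound 4 is expected to show a 2.7-fold lower number from compound 3 to compound 4 (0.43 log units; beyond the scatter). Compound 4 is therefore estimated at 80000000 nM in this assay, with a range from 30000000 nM to 200000000 nM.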

Compound 4, half-maximal inhibitory concentration: 95000000 nM
For compound 4 the middle estimate is 1.2-fold (0.07 log units) below the measured one; measured number inside the range.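

On the core of compound 3, the change of hydrogen to hydroxy on an aromatic carbon gives a 2.3-fold lower number from compound 3 to compound 4 (0.35 log units; beyond the scatter) in this assay, and on the core of compound 1 it gives a 3.1-fold lower number from compound 2 to compound 1 (0.49 log units; beyond the scatter) in the same assay, so the two steps run the same way and both lie beyond the scatter. This supports carrying the direction of the change from one core to the other, but it rests on one pair for each core, and the place differs: in compound 4 the hydroxy enters ortho to a hydroxy group and meta to a large group, so any effect of the core cannot be told apart from that of the place. Nothing shown explains the direction or size of either step.

The compounds shown leave open whether a methoxy group or an amine in the same place would lower the number as well. They also leave open whether the step would hold with a longer chain between the core and the hydrazone.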